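A few compounds are considered here, and "the series" means these few. Any claim that something is new, unique, unknown or untested is made for them only; others in the source may bear on it.

In an assay on HEK293 cells for inhibition of Neuropeptide Y receptor type 5 (Homo sapiens) (a lower number here means a stronger inhibitor, a higher number a weaker inhibitor), compound 2 `O=C(Nc1nc2cc(Cl)ccc2o1)C1CCN(C(=O)Cn2c(=O)sc3ccc(Cl)cc32)CC1` gives 4.7 nM, the higher of the two numbers recorded so far. Within the data shown here, compound 1 `COc1ccc(CNC(=O)C2CCN(C(=O)Cn3c(=O)sc4ccc(Cl)cc43)CC2)cc1` gives 1.4 nM, and the step of a 3.4-fold higher number from compound 1 to compound 2 (0.53 log units; beyond the scatter) is the only measured change on this amide-type nitrogen. Compound 3 `COc1ccc(NC(=O)C2CCN(C(=O)Cn3c(=O)sc4ccc(Cl)cc43)CC2)cn1` differs from compound 2 by 6-methoxypyridin-3-yl in place of 5-chloro-1,3-benzoxazol-2-yl on an amide-type nitrogen. The entering group is neither of the two already tried, so that measured step bears only indirectly, and a number somewhere between the two measured ones seems most plausible. Compound 3 is therefore expected to give about 3 nM, within 0.8 nM to 12 nM, a step of a 1.6-fold lower number from compound 2 to compound 3 (0.19 log units; within the scatter).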

Compound 3, half-maximal inhibitory concentration: 2.6 nM
The estimate for compound 3 lay 1.2-fold (0.06 log units) above the measured number; low and high end bracket the measured number.
By their numbers in this assay, from the lowest: compounds 1, 3 and 2 (each within the scatter of the next, the first and the last beyond it).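

In this assay, a third group on the amide-type nitrogen, 6-methoxypyridin-3-yl, gives a 1.8-fold lower number from compound 2 to compound 3 (0.26 log units; within the scatter) and a 1.9-fold higher number from compound 1 to compound 3 (0.27 log units; within the scatter), so it cannot be told apart from either earlier group. Three different aromatic groups on this nitrogen therefore all keep the numbers in the same narrow range, although 5-chloro-1,3-benzoxazol-2-yl and 4-methoxybenzyl do differ from each other. No measurement on hand offers an explanation for these numbers. As far as these compounds go, it remains open whether a carboxylic acid or a longer chain in place of these aromatic groups would stay in that range.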